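Pyrrolidine for methylamino: microsomal half-life across two cores

This account rests on a few compounds, and the source may have more. Where it says the series, first, only, none or still open, it means among the compounds named here.

Measured so far:
compound 1, `CNc1ccc2cc(-c3cc(Cl)cc(Cl)c3)c(N)nc2c1` — > 4 h (a limit of the assay)
compound 2, `Nc1nc2cc(N3CCCC3)ccc2cc1-c1cc(Cl)cc(Cl)c1` — 0.2 h
compound 3, `CNc1ccc2cc(-c3cn(C)c4ccccc34)c(N)nc2c1` — 1.3 h

In an ADME assay on microsomes from liver (Mus musculus) for metabolic stability, read by HPLC, with a stated time of 4 h (on this read-out higher numbers stand for a longer-lived compound and lower numbers for a shorter-lived compound), compound 1 gives > 4 h, which is a limit of the assay and not a number (the limit of > 4 h in this assay, at which 1 of the 3 values shown sits). In this assay compound 2 gives 0.2 h. The step between them, an at least 20-fold lower number from compound 1 to compound 2 (1.30 log units; beyond the scatter), goes with the change (pyrrolidin-1-yl in place of methylamino on an aromatic carbon). Compound 3 gives 1.3 h in this assay and stands above compound 2 by a gap beyond the scatter; compound 3 and compound 1 carry different cores, and the difference between the two cores is not broken down here.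

Compound 4, `Cn1cc(-c2cc3ccc(N4CCCC4)cc3nc2N)c2ccccc21`, has not been measured in this assay. It differs from compound 3 by pyrrolidin-1-yl in place of methylamino on an aromatic carbon. The place of the change is described in the same words for both pairs, so this is the same change as that from compound 1 to compound 2, now applied to the core of compound 3.

The expectation for compound 4 rests on the step of an at least 20-fold lower number from compound 1 to compound 2 (1.30 log units; beyond the scatter); since compound 1 sits at a limit (the limit of > 4 h in this assay, at which 1 of the 3 values shown sits), that step is only a lower bound on the true drop. A step of about a 13-fold lower number from compound 3 to compound 4 (1.11 log units; beyond the scatter) is therefore expected from compound 3 to compound 4. Compound 4 is estimated to give 0.1 h in this assay, with a likely range from 0.03 h to 0.4 h.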

Compound 4, half-life: < 0.1 h
Compound 4: no number, only a limit (the forecaster's own chance of this, stated with the estimate: 5%); the middle value lies on the limit itself.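

In this assay the change from methylamino to pyrrolidin-1-yl again goes with a large step on the second core, an at least 13-fold lower number from compound 3 to compound 4 (1.11 log units; beyond the scatter), so in both pairs the pyrrolidin-1-yl compound is the shorter-lived one by a margin beyond the scatter. Compound 4 gives < 0.1 h, which is a limit of the assay and not a number. The direction of the step therefore carries from the core of compound 1 to the core of compound 3, but these two pairs do not show whether its size carries with it: the same change on two cores in this assay, an at least 20-fold lower number (1.30 log units; beyond the scatter) from compound 1 to compound 2 and an at least 13-fold lower number (1.11 log units; beyond the scatter) from compound 3 to compound 4; the limit leaves it open whether they differ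

From the compounds shown here alone, two pairs on two cores set no rule for other cores, and the size of the drop on either core remains unknown. Going by these compounds, it also remains open which part of the change goes with the shorter half-life: a dimethylamino group or a piperidin-1-yl ring on the same aromatic carbon would help to separate the presence of a ring from the loss of the hydrogen on the nitrogen.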